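The compounds below may be only part of what the source reports. "The series", "measured", "known", "first", "only" and "open" are said of these compounds alone.

Measured so far:
Compound 1 `COc1cc(-c2ncnn2-c2ccc(Cl)cc2Cl)cc(OC)c1OC`: > 10000 nM
Compound 2 `COc1cc(-n2ncnc2-c2ccc(Cl)cc2)cc(OC)c1OC`: > 10000 nM

In a functional assay on HL-60 cells (Homo sapiens) for antiproliferative activity, read by MTT assay, with a stated time of 72 h (on this read-out lower numbers stand for stronger inhibition and higher numbers for weaker inhibition), compound 1 gives > 10000 nM, which is a limit and not a number. Compound 2 gives > 10000 nM, which is also a limit. Compound 1 therefore has no exact potency to compare, and the overall picture is the limit of > 10000 nM in this assay, at which 2 of the 2 values shown sit.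

Compound 3 `COc1cc(-c2ncnn2-c2ccc(F)cc2)cc(OC)c1OC` keeps the core of compound 1 and alters one group: 4-fluorophenyl in place of 2,4-dichlorophenyl on an aromatic nitrogen. For the measured compounds named here, no step between measured compounds shows what such a swap does in this assay. The expectation must lean on compound 1, whose > 10000 nM offers no measured activity to build on. Any gain should be modest, with weak activity still the likeliest outcome. The estimated step is an at least 1.2-fold lower number from compound 1 to compound 3 (0.09 log units; that floor lies within the scatter), expected to be small and, if it can be seen at all, towards stronger inhibition. For compound 3 the expected value is 8000 nM, with an estimated range of 1000 nM to 30000 nM.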

Compound 3, half-maximal inhibitory concentration: > 10000 nM
Compound 3 gave a limit, no number (the forecaster's own chance of this, stated with the estimate: 60%); middle value at least 1.2-fold (0.09 log units) from the limit.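

In this assay compound 3 gives > 10000 nM, which is a limit and not a number. Compound 1 also gives only a limit, so no step can be read between compound 1 and compound 3. The compounds shown leave open how any change of group on the shared core alters potency, with every result so far at one value: the limit of > 10000 nM in this assay, at which 3 of the 3 values shown sit.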